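The source may report more compounds than this note shows. Statements on the series, on what has been measured and on what is new or still open speak of the compounds shown alone.

Measured so far:
Compound 1 `Cc1nc(-c2ccccc2)c(C(=O)N2CCN(c3cccc(C)c3C)CC2)o1` — in a functional assay on HL-60 cells (Homo sapiens) for inhibition, read by MTT assay, with a stated time of 72 h (on this read-out higher numbers stand for weaker inhibition and lower numbers for stronger inhibition), compound 1 gives 35 nM.
Compound 2 `COc1cccc(N2CCN(C(=O)c3oc(C)nc3-c3ccccc3)CC2)c1` — in this assay compound 2 gives 34.8 nM.

Within the data shown here, compound 2 holds the lowest of the two numbers, but its only neighbour, compound 1, sits at a distance that is within the scatter; the one measured step, a 1.0-fold lower number from compound 1 to compound 2 (0.00 log units; within the scatter), shows that exchanging one aryl group on the ring nitrogen for another left the read-out essentially unchanged. Compound 3 `Cc1nc(-c2ccccc2)c(C(=O)N2CCN(c3cc(Cl)cc(Cl)c3)CC2)o1` is the next variation on the same position: 3,5-dichlorophenyl in place of 3-methoxyphenyl on an amine nitrogen in a ring. Among the measured compounds shown here, since the only comparable step, from compound 1 to compound 2, stayed within the scatter, no step beyond the scatter is expected in this assay for this change either, in neither direction. Compound 3 is therefore estimated at 35 nM in this assay, with a range of 14 nM to 90 nM, which corresponds to an expected step of a 1.0-fold higher number from compound 2 to compound 3 (0.00 log units; within the scatter).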

Compound 3, half-maximal inhibitory concentration: 41.8 nM
The estimate for compound 3 lay 1.2-fold (0.08 log units) below the measured number; the range from low to high includes it.
By their numbers in this assay, from the lowest: compounds 2, 1 and 3 (each within the scatter of the next).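

In this assay a second exchange of the aryl group on the amine nitrogen in a ring gives a 1.2-fold higher number from compound 2 to compound 3 (0.08 log units; within the scatter) and, taken from the other neighbour, a 1.2-fold higher number from compound 1 to compound 3 (0.08 log units; within the scatter) so both new steps stay within the scatter. The earlier pair covered only 3-methoxyphenyl and 2,3-dimethylphenyl, whereas 3,5-dichlorophenyl shows that the read-out also holds with two chlorine atoms on the ring and no hydrogen-bond acceptor in the group. No evidence is available on why these three aryl groups read alike.

The compounds shown leave open whether a benzyl group, or a phenyl bearing a carboxylic acid or an amine, on that nitrogen would give a step beyond the scatter. From the compounds shown here alone, they also keep the rest of the shared core fixed, so the effect of changing its phenyl or methyl group on this assay remains unknown.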